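The compounds below may be only part of what the source reports. "The series", "measured", "known", "first", "only" and "open" are said of these compounds alone.

In a functional assay on KB cells (Homo sapiens) for inhibition (on this read-out lower numbers stand for stronger inhibition and higher numbers for weaker inhibition), compound 1 (`COC[C@H]1OC(n2c(Cl)nc3cc(Cl)c(Cl)cc32)[C@H](O)[C@@H]1O`) gives 90000 nM, and compound 2 (`O[C@@H]1[C@@H](CCl)OC(n2c(Cl)nc3cc(Cl)c(Cl)cc32)[C@@H]1O`) gives 90000 nM, level with compound 1. Compound 3 (`O[C@@H]1[C@@H](CBr)OC(n2c(Cl)nc3cc(Cl)c(Cl)cc32)[C@@H]1O`) departs from compound 2 by one exchange: bromo in place of chloro on a saturated chain carbon bound to a saturated ring carbon. In words, this is bromo in place of chloro on a saturated chain carbon bound to a saturated ring carbon. Among the measured compounds shown here, the one measured step at this place reads no change at the digits printed from compound 1 to compound 2 (within the scatter), so no step beyond the scatter is expected in this assay. The expected step is no change at the digits printed from compound 2 to compound 3 (within the scatter). Compound 3 is estimated at 90000 nM, with an expected range of 40000 nM to 150000 nM.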

Compound 3, half-maximal inhibitory concentration: 90000 nM
The estimate for compound 3 equals the measured number at the digits printed, and the stated range covers the measured number.
By their numbers in this assay, from the lowest: compounds 1, 2 and 3 (each within the scatter of the next).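

Bromo in place of chloro gives no change at the digits printed from compound 2 to compound 3 (within the scatter) and bromo in place of methoxy gives no change at the digits printed from compound 1 to compound 3 (within the scatter) in this assay, both on a saturated chain carbon bound to a saturated ring carbon. The level seen with methoxy and chloro therefore holds for a third group, bromo, so the exchange of one halogen for another at this place shows no step beyond the scatter. No evidence given here bears on this result. Going by these compounds, how an amine, a carboxylic acid or a longer chain would read at this place remains open.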